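The source may report more compounds than this note shows. Statements on the series, on what has been measured and on what is new or still open speak of the compounds shown alone.

Measured so far:
- compound 1, `Cc1ccccc1-n1nc(C)c2c1NC(=O)[C@H](C)S[C@@H]2c1ccc(-c2ccccc2)cc1`: 990 nM
- compound 2, `COC(=O)c1cccc(-c2ccc([C@H]3S[C@@H](C)C(=O)Nc4c3c(C)nn4-c3ccccc3C)cc2)c1`: "not active" (no number reported)
- compound 3, `COc1ccccc1Oc1ccc([C@H]2S[C@@H](C)C(=O)Nc3c2c(C)nn3-c2ccccc2C)cc1`: 1700 nM

These three compounds share one core and differ only in the group attached to an aromatic carbon of a six-membered aromatic ring of carbon only. In an assay on isolated protein for agonist activity at Bile acid receptor (Homo sapiens), read by AlphaScreen, with a stated time of 30 min (on this read-out lower numbers stand for an effect already at smaller amounts and higher numbers for an effect only at larger amounts of compound), compound 1 gives 990 nM, and compound 3 gives 1700 nM; the step of a 1.7-fold higher number from compound 1 to compound 3 (0.23 log units; within the scatter) leaves the two within the scatter of each other. Compound 2 was reported as "not active" (no number reported) in this assay, so no number is available for it. On the numbers shown, compound 3 therefore sits alongside compound 1 with no real separation between them, and compound 2 gives no number for comparison.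

Compound 4, `COc1ccccc1-c1ccc([C@H]2S[C@@H](C)C(=O)Nc3c2c(C)nn3-c2ccccc2C)cc1`, differs from compound 3 as follows: 2-methoxyphenyl in place of 2-methoxyphenoxy on an aromatic carbon. The new group keeps the methoxy of compound 3 but, like the phenyl of compound 1, is joined directly to the ring. Within the data shown here, the only measured step that bears on this is a 1.7-fold higher number from compound 1 to compound 3 (0.23 log units; within the scatter), which stayed within the scatter. Nothing in this series has moved the number beyond the scatter, so the step of a 1.3-fold lower number from compound 3 to compound 4 (0.12 log units; within the scatter) is expected to be small and of no certain direction. Compound 4 is estimated to give 1300 nM in this assay, with a range from 450 nM to 4000 nM.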

Compound 4, half-maximal effective concentration: 1100 nM
Compound 4: the middle estimate sits 1.2-fold (0.07 log units) above what was measured; the range from low to high includes it.
By their numbers in this assay, from the lowest: compounds 1, 4 and 3 (each within the scatter of the next).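

Putting 2-methoxyphenyl in place of 2-methoxyphenoxy on this aromatic carbon, which by the count above takes away one oxygen and one hydrogen-bond acceptor, gives a 1.5-fold lower number from compound 3 to compound 4 (0.19 log units; within the scatter) in this assay, so the direct join and the oxygen-containing group of compound 3 cannot be told apart here. The result also provides a second comparison: methoxy in place of hydrogen on an aromatic carbon gives a 1.1-fold higher number from compound 1 to compound 4 (0.05 log units; within the scatter), so the methoxy of compound 4 cannot be told apart from the hydrogen of compound 1 either, and compounds 1, 3 and 4 now form a set of three whose numbers stay within the scatter of one another, with compound 2 still standing apart as reported "not active" and without a number. Nothing shown here accounts for why these groups read alike.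

The compounds shown leave open whether any group at this place can carry a number clearly beyond the scatter of these three. A carboxylic acid or an amine in place of the methoxy of compound 4 would test that, and would show whether such a group reads like compound 4 or like compound 2.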